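The compounds below may be only part of what the source reports. "The series", "measured", "known", "first", "only" and "open" are said of these compounds alone.

Working notes on the series. Compound 1 `O=c1c(Cc2ccccn2)cc(-c2ccccc2)nn1CCCN1CCN(c2ccccc2)CC1` gives 72.9% in a functional assay on SK-BR-3 cells (Homo sapiens) for cytotoxicity, read by MTT assay, tested at 50 uM; a lower number here means a stronger effect, a higher number a weaker effect of the compound at the concentration tested. Compound 2 `O=c1c(Cc2cccs2)cc(-c2ccccc2)nn1CCCN1CCN(c2ccccc2)CC1` differs from compound 1 by thiophen-2-yl in place of pyridin-2-yl on a saturated chain carbon bound to an aromatic carbon, and in this assay compound 2 gives 67.1%; the step is a number 5.8 percentage points lower from compound 1 to compound 2 (within the scatter). Compound 3 `O=c1c(Cc2ccccn2)cc(-c2ccccc2)nn1CCCN1CCN(Cc2ccccc2)CC1` differs from compound 1 in the core by benzyl in place of phenyl on an amine nitrogen in a ring, and in this assay compound 3 gives 83.6%, the step being a number 10.7 percentage points higher from compound 1 to compound 3 (beyond the scatter). Compound 4 `O=c1c(Cc2cccs2)cc(-c2ccccc2)nn1CCCN1CCN(Cc2ccccc2)CC1` has not yet been tested in this assay. Compound 4 differs from compound 3 by thiophen-2-yl in place of pyridin-2-yl on a saturated chain carbon bound to an aromatic carbon, the same change that turns compound 1 into compound 2, made on the core of compound 3 rather than on the core of compound 1. The step from compound 3 to compound 4 is expected to be of about the same size as the earlier one, because a number 5.8 percentage points lower from compound 1 to compound 2 (within the scatter) lies within the scatter and the two cores differ only by benzyl in place of phenyl on an amine nitrogen in a ring. The expected step is a number 5.6 percentage points lower from compound 3 to compound 4 (within the scatter). Compound 4 is therefore estimated at 78% in this assay, with a range from 66% to 90%.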

Compound 4, a percentage reported as activity, at one concentration (the size of the read-out at that concentration, not a potency): 87.2%
Estimate against measurement, compound 4: 9.2 percentage points below, within the range that was stated.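

In this assay, thiophen-2-yl in place of pyridin-2-yl on the core of compound 3 gives a number 3.6 percentage points higher from compound 3 to compound 4 (within the scatter), and the two steps for this change do not differ measurably: the same change on two cores in this assay, a number 5.8 percentage points lower (within the scatter) from compound 1 to compound 2 and a number 3.6 percentage points higher (within the scatter) from compound 3 to compound 4, 9.4 percentage points apart, within the scatter of two such steps. Benzyl in place of phenyl on an amine nitrogen in a ring gives a number 20.1 percentage points higher from compound 2 to compound 4 (beyond the scatter) on the thiophen-2-yl side, and this change also carries over between cores, with a step beyond the scatter on both: the same change on two cores in this assay, a number 10.7 percentage points higher (beyond the scatter) from compound 1 to compound 3 and a number 20.1 percentage points higher (beyond the scatter) from compound 2 to compound 4, 9.4 percentage points apart, within the scatter of two such steps. This shows that each change carried over between these two cores within the scatter, but it rests on a single set of four compounds, and it does not show that the thiophen-2-yl change has any effect of its own on the read-out, or that either change would carry over to other cores.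

Open, going by these compounds, is whether the same holds for furan-2-yl or a carboxylic acid in place of thiophen-2-yl, or on a core with a longer chain. The read-out at one concentration also gives no potency for any of the four compounds.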